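This account rests on a few compounds, and the source may have more. Where it says the series, first, only, none or still open, it means among the compounds named here.

Measured in a functional assay on L1210 cells (Mus musculus) for antiproliferative activity; on this read-out higher numbers stand for weaker inhibition and lower numbers for stronger inhibition:
- compound 1 `COc1cc(C(=O)c2sc(-c3ccc(Cl)cc3)cc2N)cc(OC)c1OC`: 93 nM
- compound 2 `COc1cc(C(=O)c2sc(-c3ccncc3)cc2N)cc(OC)c1OC`: 1810 nM
- compound 3 `COc1cc(C(=O)c2sc(-c3cc(OC)c(OC)c(OC)c3)cc2N)cc(OC)c1OC`: 2300 nM

Compound 2 lies within the scatter of compound 3 and far from compound 1 on these numbers. The next compound is compound 4 `COc1ccc(-c2cc(N)c(C(=O)c3cc(OC)c(OC)c(OC)c3)s2)cc1`, not yet measured in this assay. Its change from compound 2 is 4-methoxyphenyl in place of pyridin-4-yl on an aromatic carbon. It sits on an aromatic carbon next to the ring sulfur.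

Among the measured compounds shown here, the one measured step at this carbon is large: a 19-fold higher number from compound 1 to compound 2 (1.29 log units; beyond the scatter). There, pyridin-4-yl in place of 4-chlorophenyl raised the number, so the reverse kind of swap, to a six-membered aromatic ring of carbon only, points to a lower number. Compound 3 goes against a simple reading, since it also carries a ring of carbon only at this place and still gives 2300 nM. For the measured compounds named here, the data hold no compound with a single methoxy group on that ring, so the size stays uncertain. A sizeable step toward stronger inhibition is expected, beyond the scatter but probably short of the full distance to compound 1. The estimated step is a 7.2-fold lower number from compound 2 to compound 4 (0.86 log units; beyond the scatter). For compound 4 the estimated value is 250 nM, with an expected range of 60 nM to 1200 nM.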

Compound 4, half-maximal inhibitory concentration: 45 nM
Compound 4: middle estimate off by 5.6-fold (0.74 log units), on the high side, and the stated range ends above it.
By their numbers in this assay, from the lowest: compound 4; then compound 1; then compounds 2 and 3 (each within the scatter of the next).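

Notes on the series: at the aromatic carbon next to the ring sulfur, 4-methoxyphenyl in place of pyridin-4-yl gives a 40-fold lower number from compound 2 to compound 4 (1.60 log units; beyond the scatter) in this assay, a second large step at this carbon and the first one measured toward stronger inhibition. Methoxy in place of chloro on the same ring gives a 2.1-fold lower number from compound 1 to compound 4 (0.32 log units; beyond the scatter), a modest step but beyond the scatter, so the group on that ring also moves the number; compound 3 goes against any reading that a ring of carbon only is enough, as compound 3 gives 2300 nM in this assay and lies within the scatter of the pyridin-4-yl compound. No measurement on hand accounts for these steps.

Open, going by these compounds, is whether the methoxy oxygen matters at all: an unsubstituted phenyl, a 4-methylphenyl or a 4-ethoxyphenyl group at this carbon would test that. Also open, on these data alone, is how far the series tolerates other groups on this ring, such as an amine, a carboxylic acid or a longer alkoxy chain, and where between compound 4 and compound 3 the number turns as methoxy groups are added.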